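The source may report more compounds than this note shows. Statements on the series, on what has been measured and on what is new or still open speak of the compounds shown alone.

In a functional assay on A549 cells (Homo sapiens) for cytotoxicity, read by MTT assay, with a stated time of 24 h (a lower number here means a stronger inhibitor, a higher number a weaker inhibitor), compound 1, with the structure `CCOC(=O)N1CCC(=NNC(=O)c2ccc(C)cc2)CC1`, gives only the limit > 400000 nM. Compound 2, with the structure `CCOC(=O)N1CCC(=NNC(=O)c2ccc([N+](=O)[O-])cc2)CC1`, likewise gives only the limit > 400000 nM in this assay. The step from compound 1 to compound 2, a step that the two limits leave unreadable from compound 1 to compound 2, therefore cannot be read as a number. Compound 3, with the structure `O=C(NN=C1CC(c2ccccc2)NC(c2ccccc2)C1)c1ccc(F)cc1`, stands in the same place: in this assay it gives only the limit > 400000 nM. Within the data shown here, all three measured values thus sit at the limit of > 400000 nM in this assay, at which 3 of the 3 values shown sit, and no measured step has a readable size.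

Compound 4, with the structure `O=C(NN=C1CC(c2ccccc2)NC(c2ccccc2)C1)c1ccc(F)cc1C(F)(F)F`, differs from compound 3 in one place: trifluoromethyl in place of hydrogen on an aromatic carbon. Among the measured compounds shown here, no measured step bears directly on this change. For the measured compounds named here, the single step between measured compounds is unreadable, and the three values for compound 1, compound 2 and compound 3 are limits rather than numbers, so there is nothing that points in either direction. With no evidence to the contrary, compound 4 is expected to stay where compound 3 stands, at the limit of this assay. The step is therefore estimated as a number no higher from compound 3 to compound 4 (the limit leaves the size open), no change beyond the scatter. For compound 4 the estimate in this assay is 400000 nM, with a range from 150000 nM to 1000000 nM.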

Compound 4, half-maximal inhibitory concentration: > 400000 nM
Compound 4 gave a limit, no number (the forecaster's own chance of this, stated with the estimate: 85%); the middle value sits exactly at the limit.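

Compound 3 and compound 4 each give only a limit in this assay, so the step between them cannot be read as a number. The compounds shown leave open whether trifluoromethyl in place of hydrogen changes cytotoxicity at all, and how strong any of these compounds is, since every value stands at one limit: the limit of > 400000 nM in this assay, at which 4 of the 4 values shown sit.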